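Amide-side change in a cytotoxicity series of three measured compounds

The compounds below may be only part of what the source reports. "The series", "measured", "known", "first", "only" and "open" are said of these compounds alone.

Compound 1 `C=CC1=C(C(=O)NCCC)C(c2ccc(F)cc2)OC1` is the reference point. In a functional assay on A549 cells (Homo sapiens) for cytotoxicity, read by MTT assay, with a stated time of 24 h (on this read-out higher numbers stand for weaker inhibition and lower numbers for stronger inhibition), compound 1 gives a limit of the assay, > 100000 nM. Compound 2 `C=CC1=C(C(=O)NCc2ccc(C)cc2)C(c2ccc(F)cc2)OC1` carries 4-methylphenyl in place of ethyl on a saturated chain carbon bound to an amide-type nitrogen. In this assay compound 2 likewise returns a limit, > 100000 nM. The step that the two limits leave unreadable from compound 1 to compound 2 therefore cannot be read, as both values rest on (the limit of > 100000 nM in this assay, at which 3 of the 3 values shown sit).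

Compound 3 `C=CC1=C(C(=O)NCCC)C(c2ccc(OC)c(OC)c2)OC1` keeps the propylamino amide side of compound 1; the difference between the two cores is not broken down here. In this assay compound 3 also gives a limit, > 100000 nM. With every measured value sitting at the limit of > 100000 nM in this assay, at which 3 of the 3 values shown sit, no ordering among compounds 1, 2 and 3 can be stated.

Compound 4 `C=CC1=C(C(=O)NCc2ccc(C)cc2)C(c2ccc(OC)c(OC)c2)OC1` has not been measured. It carries 4-methylphenyl in place of ethyl on a saturated chain carbon bound to an amide-type nitrogen, the same change as from compound 1 to compound 2, at the same place. The expected step that the limit leaves unreadable from compound 3 to compound 4 rests on a step that the two limits leave unreadable from compound 1 to compound 2 being unreadable and on all three values resting at the limit of > 100000 nM in this assay, at which 3 of the 3 values shown sit. Compound 4 is therefore expected to return 150000 nM in this assay, with a range of 50000 nM to 500000 nM and a high chance that only a limit is reported.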

Compound 4, half-maximal inhibitory concentration: > 100000 nM
Compound 4: a limit, no number; the forecaster's own chance of this, stated with the estimate: 85%; the middle value does not contradict the limit.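

In this assay compound 4 gives > 100000 nM as a limit and not a number. No step can be read from compound 3 to compound 4, as both stand at the same limit: the limit of > 100000 nM in this assay, at which 4 of the 4 values shown sit. What the compounds shown leave open is whether the amide side or the core has any bearing on the read-out of this assay at all, with none of the four giving a number.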